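Dropping the Methoxy Group from Compound 3

The source may hold more compounds than are shown below. What is called first, only, known or untested is meant among the compounds shown, and "the series" means these compounds.

In a functional assay on MIA PaCa-2 cells (Homo sapiens) for cytotoxicity, read by WST assay, with a stated time of 48 h (a lower number here means a stronger inhibitor, a higher number a weaker inhibitor), compound 3 (`COc1ccc2c(C(=O)/C(C#N)=C/c3cn(Cc4ccc(Cl)cc4)c4ccccc34)c[nH]c2c1`) gives 40400 nM as its half-maximal inhibitory concentration. Among the compounds with values here, compound 2 (`N#C/C(=C\c1c[nH]c2ccccc12)C(=O)c1c[nH]c2ccccc12`) gives 36800 nM as its read-out, and these two numbers lie within the usual scatter of each other, so compound 3 stands level with the only other compound that has a true number. Compound 1 (`N#C/C(=C\c1cn(Cc2ccc(Cl)cc2)c2ccc(Br)cc12)C(=O)c1c[nH]c2ccccc12`) shows > 50000 nM and that entry is a limit of the assay, not a number.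

Compound 4 (`N#C/C(=C\c1cn(Cc2ccc(Cl)cc2)c2ccccc12)C(=O)c1c[nH]c2ccccc12`) has not been measured yet. It differs from compound 3 in one place, with hydrogen in place of methoxy on an aromatic carbon so that 6-methoxy-1H-indol-3-yl becomes 1H-indol-3-yl. Within the data shown here, no measured pair differs in one place alone, so the size of this step can only be judged from the values themselves. In this assay no step beyond the scatter is expected, a view resting on compound 3 at 40400 nM and compound 2 at 36800 nM sitting so close together. The estimated change a 1.2-fold lower number from compound 3 to compound 4 (0.06 log units; within the scatter) is expected to be small in either direction. The estimate for compound 4 is 35000 nM with an expected range of 12000 nM to 50000 nM and the result could also come back as a limit.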

Compound 4, half-maximal inhibitory concentration: > 50000 nM
Compound 4 ended at the assay's limit; the forecaster's own chance of this, stated with the estimate: 30%; middle value at least 1.4-fold (0.15 log units) away from the limit.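

Within the data shown here, removing the methoxy group from the six-membered aromatic ring gives, in this assay, an at least 1.2-fold higher number from compound 3 to compound 4 (0.09 log units; that floor lies within the scatter), the first direct reading of a change at this position, and it shows no gain in potency from the loss of that group. The other readable single change adds 4-chlorobenzyl on the aromatic nitrogen and gives an at least 1.3-fold higher number from compound 2 to compound 4 (0.13 log units; that floor lies within the scatter), so compound 4 shows no gain from that group either. The entry for compound 4 is a limit and not a number, so both steps are only floors whose true size stays unknown, and the step involving compound 1 cannot be read, with a limit on each side: the limit of > 50000 nM in this assay, at which 2 of the 4 values shown sit.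

The compounds shown leave open whether another group on this aromatic carbon, such as a hydroxyl, a fluorine or an amine, would move the number beyond the scatter around compound 3. They also leave open whether a longer chain in place of 4-chlorobenzyl on the aromatic nitrogen would give a true number rather than a limit.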